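The source may report more compounds than this note shows. Statements on the series, on what has been measured and on what is new or still open speak of the compounds shown alone.

Of the compounds shown here, three built on one shared core have been tested in a functional assay on RAW264.7 cells (Mus musculus) for inhibition, read by Griess assay, with stated times of 2 h and 24 h; a lower number here means a stronger inhibitor, a higher number a weaker inhibitor. Compound 1 `COc1ccc([C@@H]2CC(=O)c3c(O)cc(OCc4cn(Cc5ccc(C(F)(F)F)cc5)nn4)cc3O2)cc1O` gives 17700 nM, compound 2 `COc1ccc([C@@H]2CC(=O)c3c(O)cc(OCc4cn(Cc5cccc(Cl)c5)nn4)cc3O2)cc1O` gives 18200 nM, and compound 3 `COc1ccc([C@@H]2CC(=O)c3c(O)cc(OCc4cn(CC5CC5)nn4)cc3O2)cc1O` gives 11900 nM. Compound 3 carries the lowest of the three numbers, but its distance from the others is small: the step of a 1.5-fold lower number from compound 1 to compound 3 (0.17 log units; within the scatter) and the step of a 1.5-fold lower number from compound 2 to compound 3 (0.18 log units; within the scatter) both stay within the scatter, as does the step of a 1.0-fold higher number from compound 1 to compound 2 (0.01 log units; within the scatter), so no ranking among the three can be claimed.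

Compound 4 `COc1ccc([C@@H]2CC(=O)c3c(O)cc(OCc4cn(Cc5ccccc5Cl)nn4)cc3O2)cc1O` is not yet measured. It differs from compound 3 by 2-chlorophenyl in place of cyclopropyl on a saturated chain carbon bound to an aromatic nitrogen. Among the compounds with values here, the steps that bear on this change run the opposite way, from an aromatic ring to cyclopropyl, and both stayed within the scatter. Putting a chlorinated aromatic ring back in place of cyclopropyl is therefore expected to give no step beyond the scatter, with at most a slight drift upward. Compound 4 is expected to give an estimated 16000 nM in this assay, with a range from 8000 nM to 32000 nM. The expected step of a 1.3-fold higher number from compound 3 to compound 4 (0.13 log units; within the scatter) is estimated to lie within the scatter.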

Compound 4, half-maximal inhibitory concentration: 6140 nM
Compound 4: middle estimate off by 2.6-fold (0.42 log units), on the high side; measured number below the stated range.
By their numbers in this assay, from the lowest: compounds 4, 3, 1 and 2 (each within the scatter of the next, the first and the last beyond it).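

This position can respond after all. In this assay, within the data shown here, 2-chlorophenyl gives a 3.0-fold lower number from compound 2 to compound 4 (0.47 log units; beyond the scatter) and a 2.9-fold lower number from compound 1 to compound 4 (0.46 log units; beyond the scatter), both beyond the scatter, whereas no earlier step was. Compound 2 and compound 4 differ only in where the chlorine sits on the ring, so that placement alone can shift the number. Against the cyclopropyl group, the change gives a 1.9-fold lower number from compound 3 to compound 4 (0.29 log units; within the scatter), which stays within the scatter, so compound 4 cannot be ranked ahead of compound 3, and the aromatic ring alone brings no gain, as compound 1 and compound 2 also carry one.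

Nothing shown explains why the 2-chlorophenyl group behaves this way. Also open, from the compounds shown here alone, is what 2-fluorophenyl, 2-methylphenyl, or an amine or carboxylic acid at this place would give.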